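Hydroxy, methoxy, ethoxy on the shared core

The source may hold more compounds than are shown below. What is called first, only, known or untested is meant among the compounds shown, and "the series" means these compounds.

Compound 1 `CC(C)c1onc(-c2c(Cl)cccc2Cl)c1COc1ccc(-c2ccc3nc(C(=O)O)cc(O)c3c2)cc1`: 51 nM
Compound 2 `COc1cc(C(=O)O)nc2ccc(-c3ccc(OCc4c(-c5c(Cl)cccc5Cl)noc4C(C)C)cc3)cc12`: 58 nM

In a functional assay for agonist activity at Bile acid receptor (Homo sapiens), read by FRET (on this read-out lower numbers stand for an effect already at smaller amounts and higher numbers for an effect only at larger amounts of compound), compound 2 stands highest of the two numbers, with compound 1 nearest, the gap being a 1.1-fold higher number from compound 1 to compound 2 (0.06 log units; within the scatter) and so within the scatter. Compound 3 `CCOc1cc(C(=O)O)nc2ccc(-c3ccc(OCc4c(-c5c(Cl)cccc5Cl)noc4C(C)C)cc3)cc12` differs from compound 2 by methyl in place of hydrogen on a saturated chain carbon bound to an oxygen on an aromatic ring; read one bond further out, methyl to ethyl, methoxy to ethoxy. For the measured compounds named here, the only measured step, a 1.1-fold higher number from compound 1 to compound 2 (0.06 log units; within the scatter), touches the same oxygen on an aromatic ring and was within the scatter, so no step beyond the scatter is expected in this assay. Compound 3 is estimated at 65 nM, with a range from 30 nM to 140 nM. The expected step is a 1.1-fold higher number from compound 2 to compound 3 (0.05 log units; within the scatter).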

Compound 3, half-maximal effective concentration: 52 nM
For compound 3 the middle estimate is 1.3-fold (0.10 log units) above the measured one, and the stated range covers the measured number.
By their numbers in this assay, from the lowest: compounds 1, 3 and 2 (each within the scatter of the next).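

In this assay, methoxy to ethoxy (a 1.1-fold lower number from compound 2 to compound 3 (0.05 log units; within the scatter)) and ethyl in place of hydrogen on the oxygen on an aromatic ring (a 1.0-fold higher number from compound 1 to compound 3 (0.01 log units; within the scatter)) both stay within the scatter. The position therefore now has hydroxy, methoxy and ethoxy reading alike, and extending the chain by a methyl on the saturated chain carbon adds no step beyond the scatter. No evidence on the reason for this accompanies these numbers.

Open, going by these compounds, is whether a longer chain such as propoxy, or an amine or a carboxylic acid at this position, would also stay within the scatter.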